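Moving a halogen on the aryl piperazine of compound 1

This account rests on a few compounds, and the source may have more. Where it says the series, first, only, none or still open, it means among the compounds named here.

Compound 1 `CCCn1c(=O)[nH]c2nc(-c3ccc(S(=O)(=O)N4CCN(c5ccc(Br)cc5)CC4)cc3)[nH]c2c1=O` has the lowest number among the three compounds measured in an assay on CHO cells for displacement of a labelled ligand from adenosine receptor A2b (Homo sapiens), read by scintillation counting, with a stated time of 75 min, in the presence of a further agent that is not named here (on this read-out lower numbers stand for stronger inhibition and higher numbers for weaker inhibition), where compound 1 gives 0.0835 nM. Its nearest neighbour is compound 3 `CCCn1c(=O)[nH]c2nc(-c3ccc(S(=O)(=O)N4CCN(c5ccccc5C)CC4)cc3)[nH]c2c1=O`, which in this assay gives 0.432 nM; the furthest is compound 2 `CCCn1c(=O)[nH]c2nc(-c3ccc(S(=O)(=O)N(C)C)cc3)[nH]c2c1=O`, which in this assay gives 18.6 nM. Compound 4 `CCCn1c(=O)[nH]c2nc(-c3ccc(S(=O)(=O)N4CCN(c5cccc(Cl)c5)CC4)cc3)[nH]c2c1=O` differs from compound 1 in one place: 3-chlorophenyl in place of 4-bromophenyl on an amine nitrogen in a ring. Among the measured compounds shown here, only one measured step touches this part of the molecule, a 5.2-fold higher number from compound 1 to compound 3 (0.71 log units; beyond the scatter), in which the aryl group on the ring nitrogen was exchanged for another. That step is modest and points toward a higher number when the 4-bromophenyl group is replaced, so a change of similar or smaller size is expected here, since compound 4 keeps a halogen-bearing phenyl ring. The step from compound 1 to compound 4 is therefore estimated at a 2.4-fold higher number from compound 1 to compound 4 (0.38 log units; beyond the scatter). In this assay compound 4 is expected to give about 0.2 nM, within a range from 0.05 nM to 0.9 nM.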

Compound 4, inhibition constant: 0.342 nM
Beside the measured number, compound 4's estimate is 1.7-fold (0.23 log units) below it, within the range that was stated.
By their numbers in this assay, from the lowest: compound 1; then compounds 4 and 3 (each within the scatter of the next); then compound 2.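

In this assay, a second replacement of the 4-bromophenyl group also gives a higher number, a 4.1-fold higher number from compound 1 to compound 4 (0.61 log units; beyond the scatter), a modest step like the earlier 5.2-fold higher number from compound 1 to compound 3 (0.71 log units; beyond the scatter). Keeping a halogen on the phenyl ring therefore did not preserve the low number of compound 1, while a 1.3-fold lower number from compound 3 to compound 4 (0.10 log units; within the scatter) shows that 3-chlorophenyl and 2-methylphenyl cannot be told apart in this assay. No measurement is available to explain why the 4-bromophenyl group gives the lowest number of this set.

Compound 4 differs from compound 1 in both the halogen and where it sits on the phenyl ring, so the compounds shown cannot separate these two changes. From the compounds shown here alone, it also remains open how a phenyl ring bearing a methoxy group or an amine, or a pyridine ring in place of the phenyl, would behave at this position.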